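Chloro to methoxy on the aryl ring: working notes

The compounds below may be only part of what the source reports. "The series", "measured", "known", "first", "only" and "open" are said of these compounds alone.

Compound 1 `COc1ccc(/C=C(/SCc2ccc(Cl)cc2)C(=O)c2ccc(Br)cc2)cc1` and compound 2 `O=C(/C(=C\c1ccc(Cl)cc1)SCc1ccc(Cl)cc1)c1ccc(Br)cc1` differ in one place only; compound 3 `COc1ccc(C(=O)/C(=C\c2ccc(Cl)cc2)Sc2ccc(F)cc2)cc1` differs from compound 2 across a larger part of the molecule, and the difference between the two cores is not broken down here. Compound 4 `COc1ccc(/C=C(/Sc2ccc(F)cc2)C(=O)c2ccc(OC)cc2)cc1` is the methoxy counterpart of compound 3.

In a functional assay on DU-145 cells (Homo sapiens) for inhibition, read by trypan blue exclusion, with a stated time of 96 h (a lower number here means a stronger inhibitor of growth, a higher number a weaker inhibitor of growth), compound 1 gives 10000 nM. Compound 2 gives 10000 nM in this assay. The change methoxy in place of chloro on an aromatic carbon therefore produced no change at the digits printed from compound 2 to compound 1 (within the scatter). For compound 3 this assay reports only a limit, > 100000 nM, which is the limit of > 100000 nM in this assay, at which 1 of the 3 values shown sits.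

The change from compound 3 to compound 4 is methoxy in place of chloro on an aromatic carbon; its place reads word for word as for the step from compound 2 to compound 1, so it is the same change, applied on a different core. The step from compound 3 to compound 4 is expected to be a number no higher from compound 3 to compound 4 (the limit leaves the size open), resting on the flat step no change at the digits printed from compound 2 to compound 1 (within the scatter) seen for the same change. Compound 4 is estimated at 100000 nM in this assay. The expected range for compound 4 runs from 30000 nM to 300000 nM, with a real chance that again only a limit is returned.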

Compound 4, concentration for 50% growth inhibition: 25000 nM
The estimate for compound 4 lay 4.0-fold (0.60 log units) above the measured number, and the stated range ends above it.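

In this assay, the change from 4-chlorophenyl to 4-methoxyphenyl gives an at least 4.0-fold lower number from compound 3 to compound 4 (0.60 log units; beyond the scatter), so the flat result seen on the core of compound 2 does not simply carry over to the core of compound 3. Across these two pairs, the same change therefore reads differently on the two cores: the same change on two cores in this assay, no change at the digits printed (within the scatter) from compound 2 to compound 1 and an at least 4.0-fold lower number (0.60 log units; beyond the scatter) from compound 3 to compound 4, at least 4.0-fold (0.60 log units) apart, beyond the scatter of two such steps

Compound 3 is known only through a limit, so the size of the new step stays open, and the two pairs do not show which of the differences between the cores lies behind the divergence: the limit of > 100000 nM in this assay, at which 1 of the 4 values shown sits.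

Within the data shown here, with only two pairs, no general rule for carrying this change across the series can be drawn. Also open, as far as these compounds go, is how an amine or a carboxylic acid in the same place on the aromatic ring would read on either core, and whether a longer chain in place of methoxy would follow the step on the core of compound 3.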